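Aryl variation on the amide-type nitrogen of the shared core

The compounds below may be only part of what the source reports. "The series", "measured", "known", "first", "only" and "open" are said of these compounds alone.

Compound 2 `O=C(Nc1ccc(Cl)c(Cl)c1)Nc1nnc(Sc2ncnc3scc(-c4ccncc4)c23)s1` gives 14600 nM in a functional assay on T47D cells (Homo sapiens) for antiproliferative activity, read by MTT assay, with a stated time of 48 h (on this read-out lower numbers stand for stronger inhibition and higher numbers for weaker inhibition), the only number shown for the series. For compound 1 `COc1ccc(NC(=O)Nc2nnc(Sc3ncnc4scc(-c5ccncc5)c34)s2)cc1` this assay reports only a limit, > 100000 nM (the limit of > 100000 nM in this assay, at which 1 of the 2 values shown sits). For the measured compounds named here, the one measured step, an at least 6.8-fold lower number from compound 1 to compound 2 (0.83 log units; beyond the scatter), came from a different aryl group on the amide-type nitrogen. Compound 3 `O=C(Nc1ccc(Cl)c(C(F)(F)F)c1)Nc1nnc(Sc2ncnc3scc(-c4ccncc4)c23)s1` differs from compound 2 by trifluoromethyl in place of chloro on an aromatic carbon. Going by the values given here, no measured step covers this exchange, so an expected step of a 1.2-fold lower number from compound 2 to compound 3 (0.09 log units; within the scatter), within the scatter, is assumed. Compound 3 is therefore estimated at 12000 nM, with a range of 4000 nM to 40000 nM.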

Compound 3, half-maximal inhibitory concentration: 28000 nM
Beside the measured number, compound 3's estimate is 2.3-fold (0.37 log units) below it, within the range that was stated.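

In this assay, trifluoromethyl in place of chloro on this aromatic carbon gives a 1.9-fold higher number from compound 2 to compound 3 (0.28 log units; within the scatter), so this position accepts the larger group without a change that can be read. The 4-chloro-3-(trifluoromethyl)phenyl group also stands apart from 4-methoxyphenyl, with an at least 3.5-fold lower number from compound 1 to compound 3 (0.55 log units; beyond the scatter), as the 3,4-dichlorophenyl group of compound 2 did. The value of compound 1 is a limit, so this step gives only a bound: the limit of > 100000 nM in this assay, at which 1 of the 3 values shown sits.

As far as these compounds go, whether a nitrile, an amine or a carboxylic acid on this carbon would move the number beyond the scatter remains open.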